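The source may hold more compounds than are shown below. What is called first, only, known or untested is meant among the compounds shown, and "the series" means these compounds.

Working notes on the series. Compound 1 `C(=C/c1ccccc1)\C1=NCCN1` gives 18.6 nM in an assay on PC-12 cells for binding affinity to Nischarin (Rattus norvegicus); a higher number here means a weaker inhibitor, a lower number a stronger inhibitor. Compound 3 `c1ccc([C@@H]2C[C@H]2C2=NCCN2)cc1` gives 347 nM in this assay. Compound 2 `c1ccc(-c2ccccc2CCC2=NCCN2)cc1` gives 3240 nM in this assay, the highest of the three numbers; the gap to compound 3 and the wider gap to compound 1 both lie beyond the scatter. Compound 4 `c1ccc(CCC2=NCCN2)cc1` has not yet been measured in this assay. It differs from compound 2 in one place: hydrogen in place of phenyl on an aromatic carbon. Among the measured compounds shown here, no measured pair shows this change on its own, so its size is uncertain. Since the phenyl that leaves is absent from both lower-numbered compounds, a fall in the number is expected. For compound 4 the expected value in this assay is 300 nM, within 60 nM to 1500 nM. The expected step is an 11-fold lower number from compound 2 to compound 4 (1.03 log units; beyond the scatter).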

Compound 4, inhibition constant: 3720 nM
For compound 4 the middle estimate is 12-fold (1.09 log units) below the measured one; the whole stated range lies below it.
By their numbers in this assay, from the lowest: compound 1; then compound 3; then compounds 2 and 4 (each within the scatter of the next).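

Hydrogen in place of phenyl on this aromatic carbon, seen on its own for the first time, gives a 1.1-fold higher number from compound 2 to compound 4 (0.06 log units; within the scatter), so this position does not separate the two groups in this series. The absence of the phenyl therefore does not by itself bring a compound to the lower numbers of compound 1 and compound 3. Nothing available explains why the two compounds read alike.

Open, on these data alone, is whether a smaller group on the same aromatic carbon, such as methoxy, an amine or a carboxylic acid, would also read like compound 4.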